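Chloro in place of fluoro: compound 2 to compound 4

A few compounds are considered here, and "the series" means these few. Any claim that something is new, unique, unknown or untested is made for them only; others in the source may bear on it.

Of the compounds shown here, three of the shared core have been measured in a functional assay, with a stated time of 20 min; a higher number here means a weaker inhibitor, a lower number a stronger inhibitor. Compound 1 `CSc1nc(-c2ccc(N(C)C)cc2)c(C#N)c(=O)n1C` gives 78 ug/mL, compound 2 `Cn1c(NN)nc(-c2ccccc2F)c(C#N)c1=O` gives 50 ug/mL, and compound 3 `COc1ccc(-c2nc(NN)n(C)c(=O)c2C#N)cc1` gives 41 ug/mL. Compound 2 stands second highest of the three numbers; its nearest is compound 3 and its furthest is compound 1, and both gaps lie within the usual scatter, so no order among the three can be claimed.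

Compound 4 `Cn1c(NN)nc(-c2ccccc2Cl)c(C#N)c1=O` is not yet measured. It differs from compound 2 by a single exchange: chloro in place of fluoro on an aromatic carbon. Within the data shown here, no step between two measured compounds covers such an exchange, so the data give no guide to its size. The step of a 1.2-fold lower number from compound 2 to compound 4 (0.08 log units; within the scatter) is expected to stay within the scatter, in no clear direction. In this assay compound 4 is expected to give 42 ug/mL, with a range from 20 ug/mL to 95 ug/mL.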

Compound 4, half-maximal inhibitory concentration: 58 ug/mL
Beside the measured number, compound 4's estimate is 1.4-fold (0.14 log units) below it, and the stated range covers the measured number.
By their numbers in this assay, from the lowest: compounds 3, 2, 4 and 1 (each within the scatter of the next).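

In this assay, among these compounds, the exchange of fluoro for chloro, on an aromatic carbon ortho to a large group, gives the first one-place step, a 1.2-fold higher number from compound 2 to compound 4 (0.06 log units; within the scatter), so the two groups cannot be told apart at this position in this assay. This single pair shows that this position tolerates either group without a step beyond the scatter. No measurement at hand bears on the reason for this result.

As far as these compounds go, whether bromo or trifluoromethyl on this aromatic carbon would give a step beyond the scatter remains open. So does whether the same exchange reads alike with another group in place of the hydrazinyl group.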